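Compound 2 and the Step to Compound 3

The source may hold more compounds than are shown below. What is called first, only, known or untested is meant among the compounds shown, and "the series" means these compounds.

Measured in a functional assay on DU-145 cells (Homo sapiens) for inhibition, read by trypan blue exclusion, with a stated time of 72 h; on this read-out lower numbers stand for stronger inhibition and higher numbers for weaker inhibition:
Compound 1 (`COC(=O)Cn1c(=O)c(S(=O)(=O)c2ccc(F)cc2F)cc2cnc(Nc3ccc4[nH]ccc4c3)nc21`) gives 10000 nM
Compound 2 (`Cn1c(=O)c(S(=O)(=O)c2ccc(F)cc2F)cc2cnc(Nc3cccc4[nH]ccc34)nc21`) gives 750 nM

Of these two values, compound 2 holds the lower number, which stands for the stronger inhibition, and the gap to compound 1 lies beyond the usual scatter. Compound 3 (`Cn1c(=O)c(S(=O)(=O)c2ccc(F)cc2F)cc2cnc(Nc3ccc4c(c3)CC(=O)N4)nc21`) has not yet been measured in this assay. It departs from compound 2 on a nitrogen on an aromatic ring, where 1H-indol-4-yl leaves: a group of 10 heavy atoms (8 carbon, 1 nitrogen, 1 oxygen; one five-membered non-aromatic ring with 1 hetero atom, one six-membered aromatic ring of carbon only) in place of a group of 9 heavy atoms (8 carbon, 1 nitrogen; one five-membered aromatic ring with 1 hetero atom, one six-membered aromatic ring of carbon only), on a nitrogen on an aromatic ring. The five-membered aromatic ring thus gives way to a five-membered non-aromatic ring, while the six-membered aromatic ring of carbon only remains.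

Among the measured compounds shown here, no measured step shows what such a change does, so the expectation is loose. Compound 2 at 750 nM holds the lower of the two numbers, and compound 1 at 10000 nM shows how much higher a number can lie, so an upward step beyond the scatter is expected. The estimated step is a 3.3-fold higher number from compound 2 to compound 3 (0.52 log units; beyond the scatter). For compound 3 the expected value is 2500 nM, with an estimated range from 500 nM to 10000 nM.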

Compound 3, half-maximal inhibitory concentration: 100000 nM
Estimate against measurement, compound 3: 40-fold (1.60 log units) below; the measured number lies above the stated range.
By their numbers in this assay, from the lowest: compound 2; then compound 1; then compound 3.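

In this assay, among the compounds shown here, the group on the nitrogen on an aromatic ring turns out to matter a great deal: with the rest of the molecule held constant, putting the group with the five-membered non-aromatic ring in place of 1H-indol-4-yl gives a 130-fold higher number from compound 2 to compound 3 (2.12 log units; beyond the scatter), a large step and the first single-place comparison. It shows that keeping the six-membered aromatic ring of carbon only does not preserve the activity, although the entering group differs from 1H-indol-4-yl by only one additional heavy atom, and it retains the hydrogen-bond donor while adding one hydrogen-bond acceptor. No available measurement explains why the number rises so steeply.

Because the loss of the five-membered aromatic ring and the arrival of the carbonyl occur in one step, this pair cannot show how much of the change belongs to either feature alone. It also leaves open how a simple phenyl group, or a phenyl group carrying an amine or a carboxylic acid, would fare on the same nitrogen of the shared core.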